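Cytotoxicity readings that stay at the assay limit

This account rests on a few compounds, and the source may have more. Where it says the series, first, only, none or still open, it means among the compounds named here.

Compound 1 `CC(C)N(Cc1cccc(OCCCCCC(=O)O)c1)C(=O)c1ccc(-c2cccc(F)c2)cc1` carries a free acid at the end of its chain. In an ADME assay on BJ cells (Homo sapiens) for cytotoxicity, read by CellTiter-Glo and resazurin assay, with a stated time of 72 h (on this read-out lower numbers stand for an effect already at smaller amounts and higher numbers for an effect only at larger amounts of compound), compound 1 gives > 26000 nM, which is a limit of the assay and not a number. Compound 2 `CC(C)N(Cc1cccc(OCCCCCC(=O)O)c1)C(=O)c1ccc(-c2cccc(C(F)(F)F)c2)cc1` differs from compound 1 by trifluoromethyl in place of fluoro on an aromatic carbon. In this assay compound 2 gives > 26000 nM, again a limit. Compound 3 `CCOC(=O)CCCCCOc1cccc(CN(C(=O)c2ccc(-c3cccc(F)c3)cc2)C(C)C)c1` has the other core of the pair, and the two cores differ by ethyl in place of hydrogen on an oxygen next to a carbonyl group. In this assay compound 3 gives > 26000 nM, also a limit. The step that the two limits leave unreadable from compound 1 to compound 2 and the step that the two limits leave unreadable from compound 1 to compound 3 cannot be sized because every value shown sits at the limit of > 26000 nM in this assay, at which 3 of the 3 values shown sit.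

Compound 4 `CCOC(=O)CCCCCOc1cccc(CN(C(=O)c2ccc(-c3cccc(C(F)(F)F)c3)cc2)C(C)C)c1` has not been measured in this assay. It differs from compound 3 by trifluoromethyl in place of fluoro on an aromatic carbon. Among the measured compounds shown here, this is the same change, at the same place word for word, as the one behind the step that the two limits leave unreadable from compound 1 to compound 2, where both ends stayed at the limit.

Compound 4 is expected to give 30000 nM in this assay, estimated to lie between 20000 nM and 80000 nM, and most likely to come back as a limit once more. The expected step that the limit leaves unreadable from compound 3 to compound 4 rests on the earlier step that the two limits leave unreadable from compound 1 to compound 2 and on the fact that all three values shown sit at the limit of > 26000 nM in this assay, at which 3 of the 3 values shown sit.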

Compound 4, half-maximal effective concentration: < 1.3 nM
Compound 4: only a limit was reported; the forecaster's own chance of this, stated with the estimate: 85%; middle value at least 23000-fold (4.36 log units) away from the limit.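

In this assay the exchange of fluoro for trifluoromethyl on the ester core gives an at least 20000-fold lower number from compound 3 to compound 4 (4.30 log units; beyond the scatter), and adding the ethyl to the acid core of compound 2 gives an at least 20000-fold lower number from compound 2 to compound 4 (4.30 log units; beyond the scatter), so in this series the change cannot be assumed to carry from one core to another with the same outcome. Compound 1, compound 2 and compound 3 each stay at a limit, so the steps among them cannot be read, and the same change on the acid core has no size to set against the one on the ester core: the limit of > 26000 nM in this assay, at which 3 of the 4 values shown sit. The result rests on a single pair of compounds on the ester core and does not show a general rule for esters or for trifluoromethyl, and compound 4 is itself reported only as a limit, with no exact value: the limit of < 1.3 nM in this assay, at which 1 of the 4 values shown sits.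

Open, as far as these compounds go, is whether the sharp shift needs the ethyl ester and the trifluoromethyl together, or whether a methyl ester or a primary amide at the end of the chain would read as compound 4 does. Equally open, from the compounds shown here alone, is how a chloro or a nitrile in place of the trifluoromethyl, or a shorter chain, would read on the ester core.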